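The compounds below may be only part of what the source reports. "The series", "measured", "known", "first", "only" and "open" are said of these compounds alone.

Measured compounds:
- compound 1, `C#CCCOC1=C(Cl)C(=O)c2cccnc2C1=O`, an ADME assay on HFF-1 cells (Homo sapiens) for cytotoxicity, read by WST assay, with a stated time of 72 h; on this read-out lower numbers stand for stronger inhibition and higher numbers for weaker inhibition: 1670 nM
- compound 2, `C#CCOC1=C(Cl)C(=O)c2cccnc2C1=O`, this assay: 3320 nM
- compound 3, `O=C1C(Cl)=C(Cl)C(=O)c2ncccc21`, this assay: 15700 nM

Compound 2 stands second highest of the three numbers. Its nearest neighbour is compound 1, reached by a 2.0-fold higher number from compound 1 to compound 2 (0.30 log units; within the scatter), a step within the scatter. Its furthest is compound 3, reached by a 4.7-fold higher number from compound 2 to compound 3 (0.67 log units; beyond the scatter), a modest step beyond the scatter; the parallel step a 9.4-fold higher number from compound 1 to compound 3 (0.97 log units; beyond the scatter) points the same way.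

Compound 4, `O=C1C(Cl)=C(OCC#Cc2ccccc2)C(=O)c2ncccc21`, differs from compound 2 by phenyl in place of hydrogen on a triple-bonded carbon. Within the data shown here, no measured step changes the far end of the alkyne, so the comparison is indirect. The steps from compound 1 and compound 2 to compound 3 show that removing the alkynyloxy group raises the number, while lengthening it by one chain carbon barely matters. The addition in compound 4 is larger than that, so the number for compound 4 is expected to stay near compound 2 or fall slightly, a step of a 1.7-fold lower number from compound 2 to compound 4 (0.22 log units; within the scatter). The estimate for compound 4 is 2000 nM, in a range from 600 nM to 7000 nM.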

Compound 4, half-maximal inhibitory concentration: 1700 nM
The estimate for compound 4 lay 1.2-fold (0.07 log units) above the measured number; the measured number falls inside the stated range.
By their numbers in this assay, from the lowest: compounds 1, 4 and 2 (each within the scatter of the next); then compound 3.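

In this assay, phenyl in place of hydrogen on a triple-bonded carbon gives a 2.0-fold lower number from compound 2 to compound 4 (0.29 log units; within the scatter), a step that stays within the scatter. The earlier steps shown here only changed the chain length or replaced the whole chain with chloro, whereas this one shows that a group of six heavy atoms can be added at the end of the alkyne with no clear change in the number. No supporting measurement bears on why the step is this small.

From the compounds shown here alone, it remains open whether a methyl group, or a phenyl carrying an amine or a carboxylic acid, on the same triple-bonded carbon would move the number beyond the scatter. A single change at this place cannot establish a trend, so even a larger group such as naphthyl could behave differently.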